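Isobutyl for isopropyl in compound 4

The compounds below may be only part of what the source reports. "The series", "measured", "known", "first", "only" and "open" are said of these compounds alone.

In a functional assay on A549 cells (Homo sapiens) for cytotoxicity, read by MTT assay (on this read-out lower numbers stand for stronger inhibition and higher numbers for weaker inhibition), compound 2 (`CC(C)[C@H](NC(=S)Nc1ccccc1)c1nc2ccccc2[nH]1`) has the lowest number of the three measured compounds, at 5200 nM. Compound 3 (`CC(C)[C@@H](NC(=S)NCc1ccccc1)c1nc2ccccc2[nH]1`) gives 11300 nM, and compound 1 (`CC(C)[C@H](NC(=S)NCc1ccccc1)c1nc2ccccc2[nH]1`) gives 56100 nM.

Two measured steps frame the question. The large one, an 11-fold lower number from compound 1 to compound 2 (1.03 log units; beyond the scatter), puts phenyl in place of benzyl on an amide-type nitrogen. The modest one, a 5.0-fold lower number from compound 1 to compound 3 (0.70 log units; beyond the scatter), comes about because of the fact that compounds 1 and 3 differ only in the configuration as drawn, and the stereocentre involved is a saturated chain carbon.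

Compound 4 (`CC(C)C[C@H](NC(=S)Nc1ccccc1)c1nc2ccccc2[nH]1`) changes the group on that same carbon: isobutyl in place of isopropyl on a saturated chain carbon bound to an amide-type nitrogen and an aromatic carbon. This places isobutyl in place of isopropyl on a saturated chain carbon bound to an amide-type nitrogen and an aromatic carbon. Neither measured step alters this group, so neither gives its size directly. Going by the values given here, the step between compound 1 and compound 3 shows only that the number can respond to changes at this carbon, which argues for a wide range in either direction.

Among the compounds with values here, with no direct precedent, no clear move beyond the scatter is expected, and the estimated change is a 1.1-fold lower number from compound 2 to compound 4 (0.03 log units; within the scatter). For compound 4 the estimated value is 4800 nM, with an expected range of 1800 nM to 13000 nM.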

Compound 4, half-maximal inhibitory concentration: 28600 nM
For compound 4 the middle estimate is 6.0-fold (0.78 log units) below the measured one; the whole stated range lies below it.
By their numbers in this assay, from the lowest: compound 2; then compound 3; then compounds 4 and 1 (each within the scatter of the next).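

Read in this assay, a 5.5-fold higher number from compound 2 to compound 4 (0.74 log units; beyond the scatter) is the first measured step in which the group on this carbon changes, rather than its configuration as drawn. It shows that the saturated chain carbon bound to an amide-type nitrogen and an aromatic carbon does not tolerate every small change in its alkyl group: isobutyl in place of isopropyl moves the number upward, towards weaker inhibition, by a margin beyond the scatter, with phenyl on the amide-type nitrogen in both compounds. Nothing given here explains why this replacement raises the number.

The step rests on a single pair, so it does not show whether isobutyl would have the same effect with benzyl on the amide-type nitrogen, as in compound 1, or with the configuration drawn in compound 3. It also leaves open how a methyl group, a cyclohexyl ring or a longer chain on this carbon would read, and so whether the number rises steadily with the size of the group or isobutyl is a special case.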